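The compounds below may be only part of what the source reports. "The series", "measured", "known", "first", "only" and "open" are said of these compounds alone.

Measured compounds:
- compound 1, `Cc1cn([C@H]2C[C@H](SSC(Cl)(Cl)Cl)[C@@H](CO)O2)c(=O)[nH]c1=O`: < 1.5 h
- compound 2, `Cc1cn([C@H]2C[C@H](SSc3ccccc3[N+](=O)[O-])[C@@H](CO)O2)c(=O)[nH]c1=O`: < 0.167 h
- compound 3, `CCCCCCSS[C@H]1C[C@H](n2cc(C)c(=O)[nH]c2=O)O[C@@H]1CO`: < 8 h

These three share one core and differ only in the group carried on a sulfur whose other neighbour is sulfur. In a physicochemical assay for metabolic stability, in the presence of a further agent that is not named here (on this read-out higher numbers stand for a longer-lived compound and lower numbers for a shorter-lived compound), compound 2 gives < 0.167 h, which is a limit of the assay and not a number. Compound 1 also gives only a limit in this assay, (the limit of < 1.5 h in this assay, at which 1 of the 3 values shown sits), and compound 3 likewise, (the limit of < 8 h in this assay, at which 1 of the 3 values shown sits). Because all three values are limits, the steps a step that the two limits leave unreadable from compound 1 to compound 2, a step that the two limits leave unreadable from compound 1 to compound 3 and a step that the two limits leave unreadable from compound 2 to compound 3 cannot be read in size or direction.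

Compound 4, `Cc1cn([C@H]2C[C@H](SSCCCCCCO)[C@@H](CO)O2)c(=O)[nH]c1=O`, has not yet been measured. It arises from compound 2 by the change (6-hydroxyhexyl in place of 2-nitrophenyl on a sulfur). Among the measured compounds shown here, the step that bears most closely on it is the one from compound 2 to compound 3, where hexyl likewise replaced 2-nitrophenyl, but its size is unreadable. The expectation is therefore loose. Compound 4 is expected to reach 3 h, within 0.5 h to 8 h, an expected step of an at least 17-fold higher number from compound 2 to compound 4 (1.25 log units; beyond the scatter) from compound 2.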

Compound 4, half-life: < 8 h
Compound 4 ended at the assay's limit (the forecaster's own chance of this, stated with the estimate: 30%); the middle value lies beyond the limit too.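

In this assay compound 4 gives < 8 h, which is a limit of the assay and not a number. Among the compounds shown here, compound 1, compound 2 and compound 3 also sit at limits, so no step to compound 4 can be read. As far as these compounds go, the actual half-life of all four compounds stays open, and so does any difference between them.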